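Efficacy notes: amide-to-ester change on the shared core

The source may report more compounds than this note shows. Statements on the series, on what has been measured and on what is new or still open speak of the compounds shown alone.

Measured compounds:
compound 1 `COc1cccc(-c2nc(SC)nc3sc(C(=O)NCc4ccccc4)c(N)c23)c1` — 7.8%
compound 2 `CCNC(=O)c1sc2nc(SC)nc(-c3cccc(OC)c3)c2c1N` — 26.9%

Among the compounds with values here, in a functional assay on HEK293 cells for agonist activity at lutropin-choriogonadotropic hormone receptor (Homo sapiens), read by cAMP accumulation (a lower number here means a smaller maximal response, a higher number a larger maximal response), compound 2 gives 26.9%, the higher of the two numbers so far; compound 1 gives 7.8% in this assay. Within the data shown here, the only measured step, a number 19.1 percentage points higher from compound 1 to compound 2 (beyond the scatter), concerns the group on the saturated chain carbon bound to the amide-type nitrogen and is modest.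

Compound 3 `COc1cccc(-c2nc(SC)nc3sc(C(=O)OC(C)(C)C)c(N)c23)c1` is not yet measured. It differs from compound 2 by tert-butoxy in place of ethylamino on a carbonyl carbon, the change reading ethylcarbamoyl to tert-butoxycarbonyl one bond further out. Among the measured compounds shown here, no measured step alters the carbonyl substituent in this way, so the step from compound 1 to compound 2 bears only indirectly on it; the scale of that step is the only guide to how much this position can move the read-out.

For compound 3 the expected step is a number 11.9 percentage points lower from compound 2 to compound 3 (beyond the scatter), tending downward but with wide uncertainty. The estimate for compound 3 in this assay is 15%, range 2% to 40%.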

Compound 3, largest response reached (reported as efficacy), in percent of the reference or control that the assay uses: 23.8%
Estimate against measurement, compound 3: 8.8 percentage points below; low and high end bracket the measured number.
By their numbers in this assay, from the lowest: compound 1; then compounds 3 and 2 (each within the scatter of the next).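

In this assay, tert-butoxy in place of ethylamino on the carbonyl carbon gives a number 3.1 percentage points lower from compound 2 to compound 3 (within the scatter), so within this pair the change from amide to ester, with the loss of the hydrogen-bond donor, does not separate the two compounds. The comparison with the benzylamino compound, a number 16 percentage points higher from compound 1 to compound 3 (beyond the scatter), shows that compound 1 stands apart from both compound 2 and compound 3, and that a response of this size does not depend on an amide at this carbonyl carbon. Nothing available explains why the benzylamino compound gives the lowest response of the three.

An ethoxy or tert-butylamino group at this carbonyl carbon would be needed to separate the change of linking atom from the change of the group attached to it. From the compounds shown here alone, whether a carboxylic acid or a primary amide here would read with compound 1 or with compounds 2 and 3 remains open.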